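A few compounds are considered here, and "the series" means these few. Any claim that something is new, unique, unknown or untested is made for them only; others in the source may bear on it.

Measured in a physicochemical assay, read by spectrophotometry, with a stated time of 15 min; on this read-out lower numbers stand for stronger inhibition and higher numbers for weaker inhibition:
- compound 1 `O=C(CCc1nc2ccccc2c(=O)[nH]1)N/N=C/c1ccc(O)c(O)c1` gives 105000000 nM
- compound 2 `O=C(CCc1nc2ccccc2c(=O)[nH]1)N/N=C/c1ccc(O)cc1` gives 300000000 nM
- compound 3 `COc1cc(/C=N/NC(=O)CCc2nc3ccccc3c(=O)[nH]2)ccc1O` gives 290000000 nM

Compound 3 stands at the upper end of these numbers, level with compound 2: a 1.0-fold lower number from compound 2 to compound 3 (0.01 log units; within the scatter). Compound 1 lies clearly lower: a 2.8-fold higher number from compound 1 to compound 3 (0.44 log units; beyond the scatter).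

The next compound is compound 4 `O=C(CCc1nc2ccccc2c(=O)[nH]1)N/N=C/c1cc(O)c(O)c(O)c1`. The change is 3,4,5-trihydroxyphenyl in place of 4-hydroxy-3-methoxyphenyl on a carbon with a double bond to nitrogen, which puts 3,4,5-trihydroxyphenyl in place of 4-hydroxy-3-methoxyphenyl on a carbon with a double bond to nitrogen. Going by the values given here, two measured steps bear on this. Capping a hydroxy with methyl gave a 2.8-fold higher number from compound 1 to compound 3 (0.44 log units; beyond the scatter), and removing a hydroxy gave a 2.9-fold higher number from compound 1 to compound 2 (0.46 log units; beyond the scatter). Both were modest and both raised the number. Compound 4 carries no methoxy, so a modest step down in this assay is expected, towards the level of compound 1. Among the compounds with values here, no measured step shows what a further hydroxy does, so the range stays wide. The expected change is a 3.2-fold lower number from compound 3 to compound 4 (0.51 log units; beyond the scatter). For compound 4 the estimate is 90000000 nM, with an expected range from 30000000 nM to 250000000 nM.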

Compound 4, half-maximal inhibitory concentration: 45000000 nM
Compound 4: middle estimate off by 2.0-fold (0.30 log units), on the high side; the range from low to high includes it.
By their numbers in this assay, from the lowest: compound 4; then compound 1; then compounds 3 and 2 (each within the scatter of the next).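

In this assay, going by these compounds alone, the 3,4,5-trihydroxyphenyl group on the carbon with a double bond to nitrogen gives the lowest number of the series, and a further hydroxy lowers the number beyond the catechol-type level (a 2.3-fold lower number from compound 1 to compound 4 (0.37 log units; beyond the scatter)), whereas the earlier steps showed only a rise on removing or capping a hydroxy. The drop is larger against the groups with one free hydroxy, both from the 4-hydroxy-3-methoxyphenyl group (a 6.4-fold lower number from compound 3 to compound 4 (0.81 log units; beyond the scatter)) and from the 4-hydroxyphenyl group (a 6.7-fold lower number from compound 2 to compound 4 (0.82 log units; beyond the scatter)), so across these four compounds the number falls as free hydroxy groups are added, and none goes against this. Nothing measured here accounts for this trend.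

As far as these compounds go, whether an amine or a carboxylic acid on this ring could stand in for a hydroxy remains open. So does the effect of a longer chain joining the shared core to the rest of the molecule.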